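The source may hold more compounds than are shown below. What is called first, only, known or untested is meant among the compounds shown, and "the series" means these compounds.

Measured compounds:

Compound 1, `Cc1cccc(CN2CCN(C(=O)CN[C@H]3CCN(S(=O)(=O)Cc4ccccc4)C3)CC2)c1`, gives 11300 nM in a functional assay on K562 cells (Homo sapiens) for cytotoxicity, read by MTT assay, with a stated time of 48 h; on this read-out higher numbers stand for weaker inhibition and lower numbers for stronger inhibition.
Compound 2, `Cc1ccc(CN2CCN(C(=O)CN[C@H]3CCN(S(=O)(=O)Cc4ccccc4)C3)CC2)cc1`, gives 8200 nM.
Compound 3, `O=C(CN[C@H]1CCN(S(=O)(=O)Cc2ccccc2)C1)N1CCN(Cc2ccc(F)cc2)CC1`, gives 14300 nM.

Compound 3 carries the highest of the three numbers, yet it cannot be set apart from the others: the step of a 1.3-fold higher number from compound 1 to compound 3 (0.10 log units; within the scatter) and the step of a 1.7-fold higher number from compound 2 to compound 3 (0.24 log units; within the scatter) both stay within the scatter, as does the step of a 1.4-fold lower number from compound 1 to compound 2 (0.14 log units; within the scatter) between the other two. All three compounds share the same core and differ only in the small group on the benzyl ring, and none of those swaps has moved the read-out beyond what repeat measurements would show.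

Compound 4, `COc1ccc(CN2CCN(C(=O)CN[C@H]3CCN(S(=O)(=O)Cc4ccccc4)C3)CC2)cc1`, is the next member of this series. It differs from compound 3 in one place: methoxy in place of fluoro on an aromatic carbon. For the measured compounds named here, no measured step exchanges fluoro for methoxy. The step that comes closest is a 1.7-fold higher number from compound 2 to compound 3 (0.24 log units; within the scatter), where methyl and fluoro were exchanged on the same aromatic carbon, and it remained within the scatter. With every change so far on this ring leaving the number where it was, the step from compound 3 to compound 4 is expected to be a 1.4-fold lower number from compound 3 to compound 4 (0.16 log units; within the scatter), that is, nothing beyond the scatter. Compound 4 is therefore estimated at 10000 nM, with a range from 4000 nM to 25000 nM.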

Compound 4, half-maximal inhibitory concentration: 50900 nM
For compound 4 the middle estimate is 5.1-fold (0.71 log units) below the measured one, outside the stated range (above it).
By their numbers in this assay, from the lowest: compounds 2, 1 and 3 (each within the scatter of the next); then compound 4.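

In this assay, for the compounds shown here, this position turns out to matter: putting methoxy in place of fluoro, which turns the 4-fluorobenzyl group into the 4-methoxybenzyl group, is the first change to go beyond the scatter (a 3.6-fold higher number from compound 3 to compound 4 (0.55 log units; beyond the scatter)), and the higher number means weaker inhibition. The 4-methoxybenzyl compound also stands apart from both methyl-bearing compounds (a 6.2-fold higher number from compound 2 to compound 4 (0.79 log units; beyond the scatter); a 4.5-fold higher number from compound 1 to compound 4 (0.65 log units; beyond the scatter)), so compound 4 is the weakest of the four, with its steps to all the others beyond the scatter. Methyl and fluoro on this ring left the number within the scatter, whereas methoxy, which brings two heavy atoms and one hydrogen-bond acceptor in place of the single fluorine, did not, and nothing measured here explains why.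

Going by these compounds, it remains open whether the oxygen itself matters or simply the larger group, a question that a hydroxyl, an ethyl group or an amine on the same aromatic carbon could help to settle. Also open, on these data alone, is whether a longer chain such as ethoxy would push the number further in the same direction.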